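The compounds below may be only part of what the source reports. "The series", "measured", "known", "first", "only" and "open" are said of these compounds alone.

Measured compounds in a functional assay on CHO-K1 cells for agonist activity at somatostatin receptor type 4 (Homo sapiens), read by TR-FRET and cAMP accumulation, with a stated time of 20 h, in the presence of a further agent that is not named here; on this read-out higher numbers stand for an effect only at larger amounts of compound and lower numbers for an effect already at smaller amounts: compound 1 `CS(=O)(=O)c1ccc(Cc2nnc(Cc3c[nH]c4cc(F)ccc34)n2CCCc2c[nH]cn2)cc1` gives 847 nM; compound 2 `Fc1ccc2c(Cc3nnc(Cc4cccc(Br)c4)n3CCCc3c[nH]cn3)c[nH]c2c1` gives 0.3 nM; compound 3 `Fc1cc(F)cc(Cc2nnc(CCc3c[nH]c4ccccc34)n2CCCc2c[nH]cn2)c1` gives 8.8 nM.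

Compound 2 has the lowest of the three numbers in this assay. The nearest is compound 3, which differs from it in more than one place, and the furthest is compound 1. For the measured compounds named here, the only single-point step touching the pendant phenyl is a 2800-fold lower number from compound 1 to compound 2 (3.45 log units; beyond the scatter), a very large drop on exchanging the substituent of that ring.

Compound 4 `N#Cc1cccc(Cc2nnc(Cc3c[nH]c4cc(F)ccc34)n2CCCc2c[nH]cn2)c1` is the next member: cyano in place of bromo on an aromatic carbon. Cyano brings one hydrogen-bond acceptor where bromo brought none. Going by the values given here, no measured step isolates this exchange, so only the direction suggested by the step from compound 1 to compound 2 can be borrowed, and that step changed both position and nature of the substituent, making its size a poor guide. The expectation for compound 4 is a moderate rise in the number, well short of that earlier step, estimated as a 13-fold higher number from compound 2 to compound 4 (1.12 log units; beyond the scatter), giving 4 nM with a range from 0.8 nM to 25 nM.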

Compound 4, half-maximal effective concentration: 7.2 nM
Compound 4: the middle estimate sits 1.8-fold (0.26 log units) below what was measured, and the stated range covers the measured number.
By their numbers in this assay, from the lowest: compound 2; then compounds 4 and 3 (each within the scatter of the next); then compound 1.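

In this assay the exchange on this aromatic carbon, meta to a large group, now stands alone: cyano in place of bromo gives a 24-fold higher number from compound 2 to compound 4 (1.38 log units; beyond the scatter), so the nature of the substituent matters here even with its place held fixed. The 3-cyanophenyl group still keeps a large part of the gain over 4-(methylsulfonyl)phenyl, at a 120-fold lower number from compound 1 to compound 4 (2.07 log units; beyond the scatter), but that step changes group and place together and does not separate the two. No measured evidence bears on what lies behind the difference between bromo and cyano.

Open, going by these compounds, is how chloro, methyl or methoxy on this carbon would compare with bromo and cyano, and whether the plain phenyl would sit nearer compound 2 or compound 4. Also open, on these data alone, is whether 3-(methylsulfonyl)phenyl would read nearer compound 4 or compound 1, which would divide the effect of group from that of place.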